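Notes on compound 1 and the proposed compound 3

A few compounds are considered here, and "the series" means these few. Any claim that something is new, unique, unknown or untested is made for them only; others in the source may bear on it.

Measured so far:
compound 1 `Cc1cc(-c2c(C)nn(C)c2C)cnc1-c1nnc(N(C)Cc2ccc3nccn3c2)o1` — > 31600 nM
compound 2 `Cc1cc(-c2c(C)nn(C)c2C)ccc1-c1nnc(N(C)Cc2ccc3ncc(C4CCN(C)CC4)n3c2)o1` — > 31600 nM

Compound 1 `Cc1cc(-c2c(C)nn(C)c2C)cnc1-c1nnc(N(C)Cc2ccc3nccn3c2)o1` returns only a limit in an assay on COS-7 cells for inhibition of tyrosine-protein kinase receptor TYRO3 (Homo sapiens), read by ELISA, with a stated time of 1 h (on this read-out lower numbers stand for stronger inhibition and higher numbers for weaker inhibition), namely > 31600 nM. Compound 2 `Cc1cc(-c2c(C)nn(C)c2C)ccc1-c1nnc(N(C)Cc2ccc3ncc(C4CCN(C)CC4)n3c2)o1`, an extended analogue on the shared core, likewise returns only a limit, > 31600 nM. Both readings sit at the limit of > 31600 nM in this assay, at which 2 of the 2 values shown sit, so compound 1 cannot be placed against anything but the limit itself; no number exists for either compound.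

The next compound, compound 3 `Cc1cc(-c2c(C)nn(C)c2C)cnc1-c1nnc(N(C)Cc2ccc3ncc(-c4ccc(CN(C)C)nc4)n3c2)o1`, differs from compound 1 by 6-((dimethylamino)methyl)pyridin-3-yl in place of hydrogen on an aromatic carbon. For the measured compounds named here, no measured pair differs in one place, so nothing shows how an addition of this kind moves the read-out, and compound 2 gives no guidance beyond being another limit.

The expected step from compound 1 to compound 3 is therefore an at least 1.0-fold lower number from compound 1 to compound 3 (0.02 log units; that floor lies within the scatter), that is, none beyond the scatter, with the read-out most likely again stuck at a limit. Compound 3 is estimated at 30000 nM, with a plausible range from 8000 nM to 100000 nM.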

Compound 3, half-maximal inhibitory concentration: > 31600 nM
Compound 3 was reported as a limit; the forecaster's own chance of this, stated with the estimate: 70%; at least 1.0-fold (0.02 log units) between middle value and limit.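

In this assay no step can be read from compound 1 to compound 3, because both values are limits and not numbers: the limit of > 31600 nM in this assay, at which 3 of the 3 values shown sit. The compounds shown leave open how 6-((dimethylamino)methyl)pyridin-3-yl in place of hydrogen moves the read-out, and whether any compound on the shared core gives a number rather than a limit.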